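The source may hold more compounds than are shown below. What is called first, only, known or untested is meant among the compounds shown, and "the series" means these compounds.

Working notes on the series. Compound 1 `CCOc1ccc(-c2ncnn2-c2cc(OC)c(OC)c(OC)c2)cc1` in a functional assay on A549 cells (Homo sapiens) for antiproliferative activity, read by MTT assay, with a stated time of 72 h (on this read-out higher numbers stand for weaker inhibition and lower numbers for stronger inhibition), gives 100 nM. Compound 2 `COc1cc(-n2ncnc2-c2ccc(OC(C)C)cc2)cc(OC)c1OC` reaches only the limit > 10000 nM in this assay. The change methyl in place of hydrogen on a saturated chain carbon bound to an oxygen on an aromatic ring and a saturated chain carbon thus produced an at least 100-fold higher number from compound 1 to compound 2 (2.00 log units; beyond the scatter); this step ends at the limit of > 10000 nM in this assay, at which 2 of the 3 values shown sit. Compound 3 `COc1ccccc1-c1ncnn1-c1cc(OC)c(OC)c(OC)c1` also gives only the limit > 10000 nM in this assay. The difference between the core of compound 3 and that of compound 1 is not broken down here. Compound 4 `CCOc1ccccc1-c1ncnn1-c1cc(OC)c(OC)c(OC)c1` is the not yet measured partner, carrying (methyl in place of hydrogen on a saturated chain carbon bound to an oxygen on an aromatic ring). This is the same kind of change as in the measured pair, but the place differs: there the saturated chain carbon is bound to an oxygen on an aromatic ring and a saturated chain carbon, here to the oxygen alone. Since compound 3 already sits at the limit > 10000 nM, compound 4 is expected to remain at or near it, an expected step of a number no higher from compound 3 to compound 4 (the limit leaves the size open). Compound 4 is estimated at 10000 nM, between 2000 nM and 30000 nM.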

Compound 4, half-maximal inhibitory concentration: > 10000 nM
Compound 4: no number, only a limit; the forecaster's own chance of this, stated with the estimate: 70%; the middle value sits exactly at the limit.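

No step can be read between compound 3 and compound 4, as both values are limits: the limit of > 10000 nM in this assay, at which 3 of the 4 values shown sit.

The compounds shown leave open whether methoxy to ethoxy changes the read-out at all on this core.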